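This account rests on a few compounds, and the source may have more. Where it says the series, first, only, none or still open, it means among the compounds named here.

The measured compounds:

Compound 1, `Nc1nc(Cl)c2ncn(Cc3ccc(CCl)cc3)c2n1`: 26900 nM
Compound 2, `ClCc1cccc(Cn2cnc3c(Cl)nc(Cl)nc32)c1`: 4670 nM
Compound 3, `ClCc1ccc(Cn2cnc3c(Cl)nc(Cl)nc32)cc1`: 20900 nM

All three were tested in a functional assay on SN12C cells (Homo sapiens) for cytotoxicity, read by sulforhodamine B assay, with a stated time of 48 h; a lower number here means a stronger inhibitor of growth, a higher number a weaker inhibitor of growth. Compound 2 gives the lowest of the three numbers; its nearest neighbour is compound 3, and compound 1 lies furthest from it, both gaps beyond the scatter. Compound 3 and compound 1 share a core and differ in one place only, (amino in place of chloro on an aromatic carbon), and that step, a 1.3-fold higher number from compound 3 to compound 1 (0.11 log units; within the scatter), is within the scatter, so the two numbers cannot be told apart. Compound 2 and compound 3 contain the same atoms joined differently; the difference between their two cores is not broken down here.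

The unmeasured compound 4, `Nc1nc(Cl)c2ncn(Cc3cccc(CCl)c3)c2n1`, stands to compound 2 as compound 1 stands to compound 3: the change is amino in place of chloro on an aromatic carbon, and the place is described in the same words as the place of the change from compound 3 to compound 1, so it is the same change. For the measured compounds named here, since the one earlier example of this change left the number essentially unchanged, with a 1.3-fold higher number from compound 3 to compound 1 (0.11 log units; within the scatter), compound 4 is expected to stay close to compound 2, and the step is estimated as a 1.3-fold higher number from compound 2 to compound 4 (0.11 log units; within the scatter). The expectation for compound 4 in this assay is therefore 6000 nM, within a range from 2500 nM to 14000 nM, resting on a single example of this change.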

Compound 4, concentration for total growth inhibition: 15500 nM
The estimate for compound 4 lay 2.6-fold (0.41 log units) below the measured number; measured number outside the range, above it.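

In this assay, putting amino in place of chloro on an aromatic carbon, at the place between two ring nitrogen atoms, gives a modest step on the core of compound 2: a 3.3-fold higher number from compound 2 to compound 4 (0.52 log units; beyond the scatter). Set beside the only other example of this change, the step on the core of compound 2 cannot be told apart from the step on the core of compound 1, so as far as these two pairs go the change carries from one core to the other: the same change on two cores in this assay, a 1.3-fold higher number (0.11 log units; within the scatter) from compound 3 to compound 1 and a 3.3-fold higher number (0.52 log units; beyond the scatter) from compound 2 to compound 4, 2.6-fold (0.41 log units) apart, within the scatter of two such steps. This does not show that the change acts identically on both cores, since one step lies within the scatter and the other beyond it, and two pairs can neither fix the size of the step nor say what it would be on a third core.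

The compounds shown leave open how the number would move with a methoxy or a methylamino group on that same aromatic carbon. They also leave open what the chloromethyl group contributes, as all four compounds carry it, and a hydroxymethyl or a plain methyl group in its place would bear on that question.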